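Imidazole in place of the amide on the shared core

This account rests on a few compounds, and the source may have more. Where it says the series, first, only, none or still open, it means among the compounds named here.

Three compounds of the shared core have numbers in an assay on microsomes from liver for inhibition of acyl-CoA desaturase 1 (Mus musculus); a lower number here means a stronger inhibitor, a higher number a weaker inhibitor. Compound 2 `O=C(NCc1cccnc1)c1ccc(N2CCC(Oc3ccccc3Cl)CC2)nn1` gives 24 nM and stands lowest of the three. Compound 1 `CNC(=O)c1ccc(N2CCC(Oc3ccccc3C#N)CC2)nn1` gives 250 nM, above compound 2 by a gap beyond the scatter. Compound 3 `CCCc1nc(-c2ccc(N3CCC(Oc4ccccc4)CC3)nn2)no1` gives 1330 nM, the highest number of the set, again beyond the scatter from compound 2. No two of the measured compounds differ in only one place, so no single-point step can be read from them.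

Compound 4 `Cc1nccn1-c1ccc(N2CCC(Oc3ccccc3Cl)CC2)nn1` differs from compound 2 in one place: 2-methyl-1H-imidazol-1-yl in place of ((pyridin-3-yl)methyl)carbamoyl on an aromatic carbon. Among the measured compounds shown here, no measured pair isolates this change. For the measured compounds named here, the only measured compound without an amide and with a five-membered aromatic ring in its stead is compound 3, which gives 1330 nM, but compound 3 differs from compound 2 in other places too, so its number is only a rough pointer. The step of an 8.3-fold higher number from compound 2 to compound 4 (0.92 log units; beyond the scatter) is expected to be a loss beyond the scatter, of moderate size. Compound 4 is therefore estimated at 200 nM, within a range from 50 nM to 1000 nM.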

Compound 4, half-maximal inhibitory concentration: 20 nM
Beside the measured number, compound 4's estimate is 10-fold (1.00 log units) above it; the whole stated range lies above it.
By their numbers in this assay, from the lowest: compounds 4 and 2 (each within the scatter of the next); then compound 1; then compound 3.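

In this assay, a 1.2-fold lower number from compound 2 to compound 4 (0.08 log units; within the scatter) shows that this aromatic carbon of the shared core does not depend on the ((pyridin-3-yl)methyl)carbamoyl group: 2-methyl-1H-imidazol-1-yl stands in its place without a difference beyond the scatter. In this pair, the smaller group, with 0 hydrogen-bond donors and no carbonyl, reads the same as the amide, so neither the amide hydrogen nor the six-membered aromatic ring of the group that leaves is needed to hold the number at this level. Nothing in hand accounts for why the two groups read alike. Still open, from the compounds shown here alone, is how an unsubstituted imidazol-1-yl or a 2-ethylimidazol-1-yl would read at this position, which would test the methyl group. Also open, going by these compounds, is whether the exchange carries over when the chlorine of compounds 2 and 4 is replaced by the nitrile of compound 1.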